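This account rests on a few compounds, and the source may have more. Where it says the series, first, only, none or still open, it means among the compounds named here.

Working notes on the series. Compound 3 `O=C1O[C@@H](CSc2cccs2)CN1c1ccc(-n2cc(-c3ccccn3)cn2)c(F)c1` stands lowest of the three measured compounds in a physicochemical assay for solubility, read by HPLC, with a stated time of 24 h (on this read-out higher numbers stand for higher solubility and lower numbers for lower solubility), giving 8500 nM. Compound 1 `O=C1O[C@@H](CO)CN1c1ccc(-n2cc(-c3ccccn3)cn2)c(F)c1` gives 56400 nM and compound 2 `CN(CCC#N)C[C@H]1CN(c2ccc(-n3cc(-c4ccccn4)cn3)c(F)c2)C(=O)O1` gives 64500 nM; the two steps that lead to compound 3 are a 6.6-fold lower number from compound 1 to compound 3 (0.82 log units; beyond the scatter) and a 7.6-fold lower number from compound 2 to compound 3 (0.88 log units; beyond the scatter), both beyond the scatter and both modest. Compound 4 `NC(=O)[C@H]1CN(c2ccc(-n3cc(-c4ccccn4)cn3)c(F)c2)C(=O)O1` is the next member, differing from compound 3 by carbamoyl in place of ((thiophen-2-yl)sulfanyl)methyl on a saturated ring carbon. The change removes the group that accompanied the lower numbers of compound 3, so a rise in this assay is expected, of a size comparable to the two steps above. The estimated step is a 9.4-fold higher number from compound 3 to compound 4 (0.97 log units; beyond the scatter), giving for compound 4 an expected 80000 nM, in a range from 30000 nM to 200000 nM.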

Compound 4, solubility: 27200 nM
For compound 4 the middle estimate is 2.9-fold (0.47 log units) above the measured one; measured number outside the range, below it.
By their numbers in this assay, from the lowest: compound 3; then compound 4; then compounds 1 and 2 (each within the scatter of the next).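

In this assay, carbamoyl on the saturated ring carbon gives a rise over the thiophene-bearing group (a 3.2-fold higher number from compound 3 to compound 4 (0.51 log units; beyond the scatter)) but falls short of both hydroxymethyl (a 2.1-fold lower number from compound 1 to compound 4 (0.32 log units; beyond the scatter)) and ((2-cyanoethyl)(methyl)amino)methyl (a 2.4-fold lower number from compound 2 to compound 4 (0.37 log units; beyond the scatter)). Removing ((thiophen-2-yl)sulfanyl)methyl is therefore not enough at this position to reach the numbers of compound 1 and compound 2, and compound 4 takes an intermediate place. No measured evidence accounts for this order.

Open, going by these compounds, is how a carboxylic acid or a primary amine would read on the same ring carbon. Also open, on these data alone, is whether a longer chain ending in carbamoyl would follow compound 4 or compound 1.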